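Ethylamino for dimethylamino on a two-ring nucleoside-analogue core

This account rests on a few compounds, and the source may have more. Where it says the series, first, only, none or still open, it means among the compounds named here.

Compound 1 `CNc1nccc2c1ncn2C1O[C@H](CO)[C@@H](O)[C@H]1O` gives 8% in a functional assay (Homo sapiens) for inhibition of Nucleic Acid, tested at 100 uM; on this read-out lower numbers stand for less inhibition and higher numbers for more inhibition at the one concentration tested (going by the name of the read-out). Compound 2 `CN(C)c1[nH]ccc2ncnc1-2` gives 8% in this assay.

Compound 2 stands level with compound 1 at the digits recorded; the two values are within the scatter of each other, so nothing can be said about any ordering between them. Both sit at the low end of the read-out.

Compound 3 `CCNc1[nH]ccc2ncnc1-2` is not yet measured. It differs from compound 2 in one place: ethylamino in place of dimethylamino on an aromatic carbon. Among the measured compounds shown here, no step between two measured compounds isolates this change, so there is no direct precedent for its size. Because compound 2 gives 8%, the account expects compound 3 to remain at the same low level, with no step in either direction beyond the scatter. The estimated change in this assay is no change at the digits printed from compound 2 to compound 3 (within the scatter). Compound 3 is estimated to give 8%, with a range from 0% to 20%.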

Compound 3, a percentage reported as inhibition, at one concentration (the size of the read-out at that concentration, not a potency): 3%
Beside the measured number, compound 3's estimate is 5 percentage points above it, and the stated range covers the measured number.
By their numbers in this assay, from the lowest: compounds 3, 1 and 2 (each within the scatter of the next).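

Ethylamino in place of dimethylamino, on an aromatic carbon next to the ring nitrogen, gives the first step that isolates a single change at this position: in this assay it reads a number 5 percentage points lower from compound 2 to compound 3 (within the scatter) and so stays inside the usual spread of repeats. The two groups have the same heavy atoms, and the ethylamino group carries one hydrogen-bond donor where dimethylamino has none, yet this difference is not resolved by the read-out. Nothing available here bears on why the read-out stays at this low level.

On these data alone, all three compounds sit at the low end of the read-out, so it remains open whether any group at this position can lift it clear of the scatter. A primary amino group, a longer chain such as butylamino, or a cyclic amine such as morpholine could each test that.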